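The source may report more compounds than this note shows. Statements on the series, on what has been measured and on what is new or still open speak of the compounds shown alone.

Of the compounds shown here, two have been measured in a functional assay on NCI-H23 cells (Homo sapiens) for inhibition, read by sulforhodamine B assay, with a stated time of 48 h, tested at 10 uM; a lower number here means a stronger effect, a higher number a weaker effect of the compound at the concentration tested. Compound 1 `COc1cc(Cl)cc(-c2nn(-c3cccc(NC(=O)c4ccc(Cl)c(Cl)c4)c3)cc2-c2ccncc2)c1` gives 75.3% in this assay, the higher of the two numbers. Compound 2 `COc1cc(Cl)cc(-c2nn(-c3cccc(NC(=O)Nc4cc(C(F)(F)F)cc(C(F)(F)F)c4)c3)cc2-c2ccncc2)c1` gives -6.14% in this assay, a number lower than that of compound 1 by a margin beyond the usual scatter. Within the data shown here, no pair of measured compounds differs in one place only, so no single step can be read from the two values; they show only that the two structures sit far apart in this assay.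

Compound 3 `COc1cc(Cl)cc(-c2nn(-c3cccc(NC(=O)Nc4ccc(Cl)c(Cl)c4)c3)cc2-c2ccncc2)c1` is the next compound to be measured in this assay. It differs from compound 1 in one place: (3,4-dichlorophenyl)amino in place of 3,4-dichlorophenyl on a carbonyl carbon. Compound 2 carries the same carbamoyl arrangement, though with a different aryl group, and its value of -6.14% stands far below that of compound 1. Among the measured compounds shown here, on that basis a downward step is expected, a number 50.3 percentage points lower from compound 1 to compound 3 (beyond the scatter), its size uncertain since only one other carbamoyl compound has been measured. Compound 3 is expected to reach about 25% in this assay, within a range of -10% to 65%.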

Compound 3, a percentage reported as activity, at one concentration (the size of the read-out at that concentration, not a potency): 5.72%
Beside the measured number, compound 3's estimate is 19.3 percentage points above it; the range from low to high includes it.
By their numbers in this assay, from the lowest: compound 2; then compound 3; then compound 1.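

Placing (3,4-dichlorophenyl)amino in place of 3,4-dichlorophenyl on a carbonyl carbon, with the rest of compound 1 unchanged, gives a number 69.6 percentage points lower from compound 1 to compound 3 (beyond the scatter) in this assay. Among these compounds, this is the first reading of the change on its own: compound 1 and compound 2 differ in more than one place, whereas this pair keeps the same dichlorinated aryl ring and shows that the change at this position alone, which adds one nitrogen and one hydrogen-bond donor by count, is enough for a large step in this assay. Nothing measured on these compounds bears on the origin of the step.

The compounds shown leave open whether the amide hydrogen of the added amino group matters, which a methylamino group or an ether oxygen on the same carbonyl carbon would test. They also leave open whether a step of this size recurs with other aryl groups, such as 3,5-dimethoxyphenyl, or holds only with the 3,4-dichlorophenyl ring.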